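Replacing the butyl arm on the shared core of compound 1

The compounds below may be only part of what the source reports. "The series", "measured", "known", "first", "only" and "open" are said of these compounds alone.

Compound 1 `CCCCc1ccc(-c2cc(=O)c3c(o2)C(CC)(CC)C(=O)C(CC)=C3O)cc1` is the starting point of this set. In a functional assay on KB cells (Homo sapiens) for antiproliferative activity, read by sulforhodamine B assay, with a stated time of 3 days (on this read-out lower numbers stand for an effect already at smaller amounts and higher numbers for an effect only at larger amounts of compound), compound 1 gives 111 uM, the highest of the three numbers recorded so far. Compound 2 `CCC1=C(O)c2c(oc(-c3ccc(C(F)(F)F)cc3)cc2=O)C(CC)(CC)C1=O` in this assay gives 35.7 uM, and compound 3 `CCC1=C(O)c2c(oc(-c3ccc(OC)cc3)cc2=O)C(CC)(CC)C1=O` in this assay gives 17.7 uM. The step of a 3.1-fold lower number from compound 1 to compound 2 (0.49 log units; beyond the scatter) and the step of a 6.3-fold lower number from compound 1 to compound 3 (0.80 log units; beyond the scatter) both lower the number, each beyond the scatter, while the step of a 2.0-fold lower number from compound 2 to compound 3 (0.30 log units; within the scatter) stays within it. Both measured steps away from compound 1 exchange the butyl group for something else on the same aromatic carbon, and both move the number down by a modest amount.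

Compound 4 `CCC1=C(O)c2c(oc(-c3ccc(CBr)cc3)cc2=O)C(CC)(CC)C1=O` differs from compound 1 by bromo in place of propyl on a saturated chain carbon bound to an aromatic carbon. For the measured compounds named here, no measured pair shows this particular exchange. The two steps that bear on it, a 3.1-fold lower number from compound 1 to compound 2 (0.49 log units; beyond the scatter) and a 6.3-fold lower number from compound 1 to compound 3 (0.80 log units; beyond the scatter), agree in direction, so a modest drop from compound 1 is the working expectation, with wide uncertainty since bromine enters nowhere else in the set. The step of a 2.8-fold lower number from compound 1 to compound 4 (0.44 log units; beyond the scatter) is therefore the expected shift. Compound 4 is estimated at 40 uM in this assay, within a range from 15 uM to 110 uM.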

Compound 4, concentration for half-maximal effect: > 46.5 uM
Compound 4 ended at the assay's limit (the forecaster's own chance of this, stated with the estimate: 5%); middle value at least 1.1-fold (0.06 log units) from the limit.
By their numbers in this assay, from the lowest: compounds 3 and 2 (each within the scatter of the next); then compound 1.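

In this assay compound 4 carries a limit and not a number: the limit of > 46.5 uM in this assay, at which 1 of the 4 values shown sits. Even so, the limit separates one exchange on the aromatic carbon: bromomethyl in place of methoxy gives an at least 2.6-fold higher number from compound 3 to compound 4 (0.41 log units; beyond the scatter), while bromomethyl in place of trifluoromethyl gives an at least 1.3-fold higher number from compound 2 to compound 4 (0.11 log units; that floor lies within the scatter), so that second floor does not set the two groups apart. The step between the butyl and bromomethyl compounds cannot be read, so the lower numbers seen when trifluoromethyl or methoxy replaces butyl are not shown to extend to bromomethyl, and these data cannot place bromomethyl relative to butyl.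

The compounds shown leave open where the actual number for compound 4 lies, and so whether the trifluoromethyl and bromomethyl compounds truly differ. They also leave open how an amine, a carboxylic acid or a shorter chain such as ethyl on the same aromatic carbon would compare with methoxy and butyl on the shared core.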